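The compounds below may be only part of what the source reports. "The series", "measured", "known", "first", "only" and "open" are said of these compounds alone.

Measured compounds:
- compound 1, `COc1ccc(-n2cc(NC(=O)c3cccc(NS(=O)(=O)c4ccccc4)c3)cn2)cc1`: 18700 nM
- compound 2, `COc1cccc(-n2cc(NC(=O)c3cccc(NS(=O)(=O)c4ccc(Cl)cc4)c3)cn2)c1`: 9430 nM
- compound 3, `Cn1cc(NC(=O)c2ccc(NS(=O)(=O)c3ccccc3)cc2)cn1`: 58700 nM

In a functional assay on MCF7 cells (Homo sapiens) for inhibition, read by MTT assay, with a stated time of 48 h (on this read-out lower numbers stand for stronger inhibition and higher numbers for weaker inhibition), compound 3 gives the highest number of the three measured compounds; both compound 1 and compound 2 lie beyond the scatter below it, and both carry an aryl group on the ring nitrogen where compound 3 carries only a methyl. Compound 4, `COc1cccc(-n2cc(NC(=O)c3ccc(NS(=O)(=O)c4ccccc4)cc3)cn2)c1`, has not yet been measured. It differs from compound 3 by 3-methoxyphenyl in place of methyl on an aromatic nitrogen. Since the two measured compounds bearing an aryl group in this position both sit well below compound 3, a step toward a lower number is expected for compound 4, of about a 3.3-fold lower number from compound 3 to compound 4 (0.51 log units; beyond the scatter). Compound 4 is therefore estimated at 18000 nM, within a range from 6000 nM to 50000 nM.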

Compound 4, half-maximal inhibitory concentration: 28400 nM
For compound 4 the middle estimate is 1.6-fold (0.20 log units) below the measured one, within the range that was stated.
By their numbers in this assay, from the lowest: compounds 2, 1 and 4 (each within the scatter of the next, the first and the last beyond it); then compound 3.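

In this assay, putting 3-methoxyphenyl in place of methyl on this aromatic nitrogen gives a 2.1-fold lower number from compound 3 to compound 4 (0.32 log units; beyond the scatter). Going by these compounds alone, this is the first comparison in which nothing else changes, since compound 1 and compound 2 each differ from compound 3 in more than one place, and it shows that the larger group brings only a modest gain here. Nothing available explains this step.
Still open, from the compounds shown here alone, is whether the ring alone or its methoxy group goes with the step: a plain phenyl or a longer chain such as butyl on this nitrogen would separate the two.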